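The source may report more compounds than this note shows. Statements on the series, on what has been measured and on what is new or still open speak of the compounds shown alone.

Measured compounds:
compound 1 `Cc1cn(C2CCN(Cc3cccc(Oc4ccc(Cl)cc4)c3)CC2)c(=O)[nH]c1=O` — 25100 nM
compound 2 `Cc1cn(C2CCN(Cc3cccc(Oc4ccc(F)c(F)c4)c3)CC2)c(=O)[nH]c1=O` — > 64000 nM
compound 3 `Cc1cn(C2CCN(Cc3cccc(Oc4ccc(O)cc4)n3)CC2)c(=O)[nH]c1=O` — "not determined" (no result reported)

Going by the values given here, in an ADME assay on MRC5 cells (Homo sapiens) for cytotoxicity, read by fluorescence and resazurin assay, with a stated time of 3 days (on this read-out lower numbers stand for stronger inhibition and higher numbers for weaker inhibition), compound 1 gives 25100 nM, the only plain number among the three entries. Compound 2 reaches only a limit of this assay, > 64000 nM, and no number is known for it. For compound 3 no result was reported in this assay. Among the compounds with values here, the one measured step is an at least 2.5-fold higher number from compound 1 to compound 2 (0.40 log units; beyond the scatter), which runs into (the limit of > 64000 nM in this assay, at which 1 of the 3 values shown sits).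

Compound 4 `Cc1cn(C2CCN(Cc3cccc(Oc4cccc(C(F)(F)F)c4)c3)CC2)c(=O)[nH]c1=O` differs from compound 1 by 3-(trifluoromethyl)phenyl in place of 4-chlorophenyl on an oxygen on an aromatic ring. Within the data shown here, the only step that bears on this change, an at least 2.5-fold higher number from compound 1 to compound 2 (0.40 log units; beyond the scatter), also swaps the 4-chlorophenyl on that oxygen for a fluorinated phenyl and moves the number upward to the limit, so a step in the same direction, of modest size or none beyond the scatter, is expected here, with a real chance that compound 4 also ends at the limit. The expected step is a 1.4-fold higher number from compound 1 to compound 4 (0.14 log units; within the scatter). Compound 4 is therefore estimated at 35000 nM, within 12000 nM to 100000 nM.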

Compound 4, half-maximal inhibitory concentration: 12400 nM
Estimate against measurement, compound 4: 2.8-fold (0.45 log units) above, and the stated range covers the measured number.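

In this assay, the group on the oxygen on an aromatic ring can shift the number downward as well as upward: 3-(trifluoromethyl)phenyl in place of 4-chlorophenyl gives a 2.0-fold lower number from compound 1 to compound 4 (0.31 log units; beyond the scatter). The same group in place of 3,4-difluorophenyl gives an at least 5.1-fold lower number from compound 2 to compound 4 (0.71 log units; beyond the scatter), so the two fluorinated phenyl groups do not read alike here. That second step is only a bound, as the value of compound 2 is a limit of the assay: the limit of > 64000 nM in this assay, at which 1 of the 4 values shown sits.

The compounds shown do not separate the identity of the substituent from where it sits on the phenyl, and compound 3, with no result reported in this assay, adds nothing to this. On these data alone, how an unsubstituted phenyl, or an amine or a carboxylic acid on that phenyl, would read here stays open.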